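The source may hold more compounds than are shown below. What is called first, only, known or untested is meant among the compounds shown, and "the series" means these compounds.

The measured compounds, all in an assay for binding affinity to 5-hydroxytryptamine receptor 1F (Homo sapiens), read by radioligand binding; a higher number here means a weaker inhibitor, a lower number a stronger inhibitor:

Compound 1, `CCN1CCC(c2c[nH]c3ccc(NC(=O)c4ccc(F)cc4)nc23)CC1`, gives 170 nM.
Compound 2, `CCCN1CCC(c2c[nH]c3ccc(NC(=O)c4ccc(F)cc4)nc23)CC1`, gives 18 nM.
Compound 3, `CC(=O)Nc1ccc2[nH]cc(C3CCNCC3)c2n1`, gives 45 nM.

Compound 1 and compound 2 share one core and differ only by methyl in place of hydrogen on a saturated chain carbon, two bonds along the chain from an amine nitrogen in a ring. In this assay this change gave a 9.4-fold lower number from compound 1 to compound 2 (0.98 log units; beyond the scatter). Compound 3 stands on another core; the difference between the two cores is not broken down here. Its number sits between those of compound 1 and compound 2.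

Compound 4, `CCC(=O)Nc1ccc2[nH]cc(C3CCNCC3)c2n1`, has not yet been measured. It differs from compound 3 by methyl in place of hydrogen on a saturated chain carbon bound to a carbonyl carbon. Among the compounds with values here, this is the same kind of change as the one from compound 1 to compound 2, but not the same: in the earlier pair the added group sits on a saturated chain carbon, two bonds along the chain from an amine nitrogen in a ring, whereas in the new pair it sits on a saturated chain carbon bound to a carbonyl carbon. Both the place and the core differ, so the earlier step is only a loose guide.

In this assay compound 4 is expected to give 25 nM, with a likely range from 8 nM to 70 nM. The estimated step from compound 3 is a 1.8-fold lower number from compound 3 to compound 4 (0.26 log units; within the scatter), a smaller step than the earlier one. This rests on compound 3 giving 45 nM and on the earlier result a 9.4-fold lower number from compound 1 to compound 2 (0.98 log units; beyond the scatter), tempered by the different place of the change.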

Compound 4, inhibition constant: 35 nM
Beside the measured number, compound 4's estimate is 1.4-fold (0.15 log units) below it; the measured number falls inside the stated range.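

In this assay, within the data shown here, methyl in place of hydrogen on a saturated chain carbon bound to a carbonyl carbon gave a 1.3-fold lower number from compound 3 to compound 4 (0.11 log units; within the scatter), so on this core the change produced no step that can be told apart from repeat measurement. The same kind of change therefore did not carry over in size from one core to the other: the same change on two cores in this assay, a 9.4-fold lower number (0.98 log units; beyond the scatter) from compound 1 to compound 2 and a 1.3-fold lower number (0.11 log units; within the scatter) from compound 3 to compound 4, 7.3-fold (0.87 log units) apart, beyond the scatter of two such steps. This does not show what lies behind the gap: the two pairs differ in core and also in the place of the change, one on a saturated chain carbon two bonds along the chain from an amine nitrogen in a ring, the other on a saturated chain carbon bound to a carbonyl carbon, and a single pair of each kind cannot separate those two differences.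

The compounds shown leave open whether a longer chain on the carbonyl, such as butanoyl, or a branched one, such as isobutyryl, would give a step beyond the scatter on the core of compound 3. They also leave open how an ethyl or a propyl group on the amine nitrogen in the ring would read alongside the acetamido or propanoylamino group.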